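The source may hold more compounds than are shown below. What is called first, only, known or untested is meant among the compounds shown, and "the series" means these compounds.

In a functional assay on MCF7 cells (Homo sapiens) for inhibition, read by MTT assay, with a stated time of 48 h (a lower number here means a stronger inhibitor, a higher number a weaker inhibitor), the measured compounds are:

Compound 1 `CCOC(=O)C1=C(NN=C(C(C)=O)C(C)=O)Nc2[nH]nc(C)c2C1c1ccc(N(C)C)cc1`: 9740 nM
Compound 2 `CCOC(=O)C1=C(N)Nc2[nH]nc(C)c2C1c1ccc(N(C)C)cc1`: 5060 nM
Compound 3 `CCOC(=O)C1=C(N/N=C(/C(=O)Br)c2ccc(Cl)cc2)Nc2[nH]nc(C)c2C1c1ccc(N(C)C)cc1`: 46300 nM

Compound 3 has the highest number of the three and is thus the weakest inhibitor. Compound 4 `CCOC(=O)C1=C(N/N=C(/C(C)=O)C(=O)OCC)Nc2[nH]nc(C)c2C1c1ccc(N(C)C)cc1`, not yet measured, differs from it by a group of 10 heavy atoms (6 carbon, 1 nitrogen, 3 oxygen; no ring) in place of a group of 12 heavy atoms (8 carbon, 1 nitrogen, 1 oxygen, 1 chlorine, 1 bromine; one six-membered aromatic ring of carbon only), on an amine nitrogen. The nearest guide is a 4.8-fold higher number from compound 1 to compound 3 (0.68 log units; beyond the scatter), which replaces one group with no ring by the group containing the aromatic ring. a 9.2-fold higher number from compound 2 to compound 3 (0.96 log units; beyond the scatter) also ends at the higher number, while a 1.9-fold lower number from compound 1 to compound 2 (0.28 log units; within the scatter) stays within the scatter. Removing the aromatic ring should therefore lower the number in this assay by a similar amount. The expected step is a 3.9-fold lower number from compound 3 to compound 4 (0.59 log units; beyond the scatter). Compound 4 is estimated at 12000 nM, with an expected range of 4500 nM to 32000 nM.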

Compound 4, half-maximal inhibitory concentration: > 100000 nM
Compound 4 was reported as a limit; the forecaster's own chance of this, stated with the estimate: 3%; middle value at least 8.3-fold (0.92 log units) from the limit.
By their numbers in this assay, from the lowest: compounds 2 and 1 (each within the scatter of the next); then compound 3. At a limit, above all of these: compound 4.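

In this assay compound 4 is reported only as a limit of the assay: the limit of > 100000 nM in this assay, at which 1 of the 4 values shown sits.

The earlier compounds shown here tied the higher number to the aromatic ring, yet a group with no ring on this amine nitrogen goes further still: an at least 2.1-fold higher number from compound 3 to compound 4 (0.33 log units; beyond the scatter). The two groups with no ring also differ clearly, with an at least 10-fold higher number from compound 1 to compound 4 (1.01 log units; beyond the scatter), and the change from the hydrogen atom is large, with an at least 19-fold higher number from compound 2 to compound 4 (1.29 log units; beyond the scatter).

From the compounds shown here alone, how far compound 4 lies past its limit stays open. So does whether a short alkyl chain or a carboxylic acid on this nitrogen would stay close to compound 2.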